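The source may hold more compounds than are shown below. What is called first, only, known or untested is meant among the compounds shown, and "the series" means these compounds.

Working notes on the series built on the core of compound 1 (`COc1ccc(/C=C/C(=O)Nc2cc3c(Nc4ccc(F)c(Cl)c4)ncnc3cc2O[C@H]2CCOC2)c(OC)c1`), varied only at the phenyl group on a double-bonded chain carbon bound to a double-bonded chain carbon. In a functional assay on MCF7 cells (Homo sapiens) for cytotoxicity, read by MTT assay, with a stated time of 72 h (on this read-out lower numbers stand for stronger inhibition and higher numbers for weaker inhibition), compound 1 gives 28600 nM, compound 2 (`N#Cc1ccc(/C=C/C(=O)Nc2cc3c(Nc4ccc(F)c(Cl)c4)ncnc3cc2O[C@H]2CCOC2)cc1`) gives 9830 nM and compound 3 (`O=C(/C=C/c1cc(Br)c(O)c(Br)c1)Nc1cc2c(Nc3ccc(F)c(Cl)c3)ncnc2cc1O[C@H]1CCOC1`) gives 30600 nM. Compound 3 therefore stands at the high end of the three numbers, level with compound 1 and clear of compound 2. The two steps that fix this position are a 1.1-fold higher number from compound 1 to compound 3 (0.03 log units; within the scatter) and a 3.1-fold higher number from compound 2 to compound 3 (0.49 log units; beyond the scatter).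

Next is compound 4 (`COc1cc(/C=C/C(=O)Nc2cc3c(Nc4ccc(F)c(Cl)c4)ncnc3cc2O[C@H]2CCOC2)cc(OC)c1O`), with 4-hydroxy-3,5-dimethoxyphenyl in place of 3,5-dibromo-4-hydroxyphenyl on a double-bonded chain carbon bound to a double-bonded chain carbon. For the measured compounds named here, no measured step makes this exact exchange. The closest evidence is the exchange of 2,4-dimethoxyphenyl for 3,5-dibromo-4-hydroxyphenyl, a 1.1-fold higher number from compound 1 to compound 3 (0.03 log units; within the scatter), which stays within the scatter. The steps involving 4-cyanophenyl, a 2.9-fold lower number from compound 1 to compound 2 (0.46 log units; beyond the scatter) and a 3.1-fold higher number from compound 2 to compound 3 (0.49 log units; beyond the scatter), are modest and show the size that a change at this place has reached so far. No step beyond the scatter is therefore expected in this assay, and any shift is more likely downward, since compound 3 already sits at the high end. The estimated step is a 1.5-fold lower number from compound 3 to compound 4 (0.18 log units; within the scatter). For compound 4 the estimated value is 20000 nM, with an expected range of 8000 nM to 50000 nM.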

Compound 4, half-maximal inhibitory concentration: 30500 nM
Compound 4: middle estimate off by 1.5-fold (0.18 log units), on the low side; low and high end bracket the measured number.
By their numbers in this assay, from the lowest: compound 2; then compounds 1, 4 and 3 (each within the scatter of the next).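

In this assay the exchange of 3,5-dibromo-4-hydroxyphenyl for 4-hydroxy-3,5-dimethoxyphenyl gives a 1.0-fold lower number from compound 3 to compound 4 (0.00 log units; within the scatter) and so does not separate the pair, even though the entering group has more heavy atoms and more hydrogen-bond acceptors. Compound 4 also stands level with the 2,4-dimethoxyphenyl analogue, at a 1.1-fold higher number from compound 1 to compound 4 (0.03 log units; within the scatter) within this series, whereas a 3.1-fold higher number from compound 2 to compound 4 (0.49 log units; beyond the scatter) is a modest separation, so the three compounds with methoxy or bromine substituents form one level group and only the 4-cyanophenyl compound 2 lies apart from them. No supporting measurement is available to account for this level group or for the position of compound 2.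

The compounds shown leave open whether the separation of compound 2 belongs to the nitrile specifically, as it is the only compound in the series that carries one. They also leave open whether a phenyl group carrying an amine or a carboxylic acid at this place would stand with compound 2, with the level group or apart from both.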